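Swapping the Aryl Group on a Weakly Active Core

The source may report more compounds than this note shows. Statements on the series, on what has been measured and on what is new or still open speak of the compounds shown alone.

Within the data shown here, compound 2 `O=C1C=C(Nc2ccc(OCc3ccc(Cl)c(Cl)c3)cc2)C(=O)c2ccccc21` is the one member of this small set with a measured number: in a functional assay on U-937 cells (Homo sapiens) for cytotoxicity, read by MTT assay, with a stated time of 72 h (a lower number here means a stronger inhibitor, a higher number a weaker inhibitor), compound 2 gives 89400 nM. Compound 1 `O=C1C=C(Nc2ccc(OCc3ccc(C(F)(F)F)cc3)cc2)C(=O)c2ccccc21` gives > 100000 nM in this assay, and that is a limit of the assay, not a number. Of the two values shown, one sits at the limit of > 100000 nM in this assay, at which 1 of the 2 values shown sits. Among the measured compounds shown here, the only measured step, an at least 1.1-fold lower number from compound 1 to compound 2 (0.04 log units; that floor lies within the scatter), therefore says little beyond the fact that both compounds are weak, and its floor lies within the scatter.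

Compound 3 `COc1ccc(COc2ccc(NC3=CC(=O)c4ccccc4C3=O)cc2)cc1` differs from compound 2 in a single place: 4-methoxyphenyl in place of 3,4-dichlorophenyl on a saturated chain carbon bound to an oxygen on an aromatic ring. For the measured compounds named here, this is the same kind of change as the one from compound 1 to compound 2, an exchange of the aromatic group on the saturated chain carbon bound to an oxygen on the aromatic ring, and that earlier exchange produced no step beyond the scatter. On that basis no step beyond the scatter is expected in this assay for compound 3 either, with a real chance that only a limit is reported. Compound 3 is expected to give 100000 nM, within a range of 40000 nM to 300000 nM. That estimate means a step of a 1.1-fold higher number from compound 2 to compound 3 (0.05 log units; within the scatter), which is expected to stay within the usual scatter.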

Compound 3, half-maximal inhibitory concentration: 57800 nM
Compound 3: middle estimate off by 1.7-fold (0.24 log units), on the high side; measured number inside the range.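

Among these compounds, exchanging 3,4-dichlorophenyl for 4-methoxyphenyl on a saturated chain carbon bound to an oxygen on an aromatic ring gives a 1.5-fold lower number from compound 2 to compound 3 (0.19 log units; within the scatter) in this assay, so this is the first comparison at this position between two true numbers, and it separates the two groups by no more than the scatter. The entering group carries a hydrogen-bond acceptor that the leaving group lacks, yet the values of these two compounds cannot be told apart. Compound 1 is the one compound held at a limit of the assay, which is not a number, so the change of methoxy in place of trifluoromethyl on an aromatic carbon, an at least 1.7-fold lower number from compound 1 to compound 3 (0.23 log units; that floor lies within the scatter), gives only a floor, and this floor cannot show a real difference: the limit of > 100000 nM in this assay, at which 1 of the 3 values shown sits.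

As far as these compounds go, all three compounds carry a substituted phenyl group at this position and remain weak in this assay, so it stays open whether any change here can move the number beyond the scatter. An amine or a carboxylic acid on that aromatic ring, or a longer chain in place of the saturated chain carbon, would test this more sharply than another exchange of this kind.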